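Allylamino to Ethylamino on a Shared Thiadiazole Core

The compounds below may be only part of what the source reports. "The series", "measured", "known", "first", "only" and "open" are said of these compounds alone.

Measured compounds:
compound 1 `COCCNc1nnc(SCC(=O)N(Cc2cccc([N+](=O)[O-])c2)c2ccc(F)cc2)s1`: 26.9%
compound 2 `C=CCNc1nnc(SCC(=O)N(Cc2cccc([N+](=O)[O-])c2)c2ccc(F)cc2)s1`: 20.5%

In an assay on isolated protein for inhibition of Amine oxidase [flavin-containing] A (Homo sapiens), read by fluorescence and Amplex Red, with a stated time of 30 min, tested at 1 nM (on this read-out lower numbers stand for a weaker effect and higher numbers for a stronger effect at the one concentration tested), compound 1 gives 26.9% and compound 2 gives 20.5%. Within the data shown here, compound 2 has only one measured neighbour, compound 1, and the step of a number 6.4 percentage points lower from compound 1 to compound 2 (within the scatter) keeps the two within the scatter of each other. Compound 3 `CCNc1nnc(SCC(=O)N(Cc2cccc([N+](=O)[O-])c2)c2ccc(F)cc2)s1` differs from compound 2 by methyl in place of vinyl on a saturated chain carbon bound to a nitrogen on an aromatic ring. Among the measured compounds shown here, the one measured step that bears on this change is a number 6.4 percentage points lower from compound 1 to compound 2 (within the scatter), so no step beyond the scatter is expected for compound 3, and the expected step is a number 1.5 percentage points higher from compound 2 to compound 3 (within the scatter). Compound 3 is therefore estimated at 22%, with a range from 8% to 36%.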

Compound 3, a percentage reported as inhibition, at one concentration (the size of the read-out at that concentration, not a potency): 21%
The estimate for compound 3 lay 1 percentage points above the measured number, and the stated range covers the measured number.
By their numbers in this assay, from the lowest: compounds 2, 3 and 1 (each within the scatter of the next).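

In this assay, methyl in place of vinyl gives a number 0.5 percentage points higher from compound 2 to compound 3 (within the scatter), and hydrogen in place of methoxy gives a number 5.9 percentage points lower from compound 1 to compound 3 (within the scatter). Neither removing the double bond outside aromatic rings nor removing the methoxy therefore shifts the read-out beyond the scatter, so this position has so far tolerated all three side chains alike. No other measurement is available to explain this result. From the compounds shown here alone, whether a carboxylic acid, an amine or a longer chain on this saturated chain carbon would move the inhibition beyond the scatter remains open.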